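The compounds below may be only part of what the source reports. "The series", "measured", "known", "first", "only" and "open" are said of these compounds alone.

In a functional assay on HepG2 cells (Homo sapiens) for cytotoxicity, read by MTT assay, with a stated time of 24 h (on this read-out lower numbers stand for stronger inhibition and higher numbers for weaker inhibition), three compounds have been measured so far. Compound 1 `COc1cc(/C=C2\CN(C)C/C(=C\c3ccncc3)C2=O)cc(OC)c1` gives 9500 nM, compound 2 `O=C1/C(=C/c2cccnc2)CN(S(=O)(=O)c2ccccc2)C/C1=C\c1ccccc1F` gives 8210 nM, and compound 3 `O=C1/C(=C/c2ccncc2)CN(S(=O)(=O)c2ccccc2)C/C1=C\c1ccccc1F` gives 5800 nM, which lies within the usual scatter of the other two. Compound 4 `O=C1/C(=C/c2ccncc2)CN(S(=O)(=O)c2ccc(Cl)cc2)C/C1=C\c1ccccc1F` carries a single change from compound 3: chloro in place of hydrogen on an aromatic carbon, with chloro in place of hydrogen on an aromatic carbon. For the measured compounds named here, the only measured step, a 1.4-fold lower number from compound 2 to compound 3 (0.15 log units; within the scatter), swaps pyridin-3-yl for pyridin-4-yl elsewhere in the molecule and stays within the scatter. Going by the values given here, no measured step touches this phenyl, so the expectation in this assay is no shift beyond the scatter. The estimated step is a 1.2-fold lower number from compound 3 to compound 4 (0.06 log units; within the scatter). Compound 4 is expected at 5000 nM, with an estimated range from 2000 nM to 11000 nM.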

Compound 4, half-maximal inhibitory concentration: 5300 nM
For compound 4 the middle estimate is 1.1-fold (0.03 log units) below the measured one; low and high end bracket the measured number.
By their numbers in this assay, from the lowest: compounds 4, 3, 2 and 1 (each within the scatter of the next).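

In this assay, for the compounds shown here, the earlier compounds offered no step on the phenyl of the phenylsulfonyl group, and this one reads a 1.1-fold lower number from compound 3 to compound 4 (0.04 log units; within the scatter). At this position, para to a large group, a single chlorine atom in place of hydrogen therefore produces no shift beyond the scatter. Nothing measured here bears on the reason for this result. From the compounds shown here alone, whether an amine or a carboxylic acid at the same position would shift the number remains open. So does whether chloro on another carbon of this phenyl would behave in the same way.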